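Methyl to Chloro Ortho to the Hydroxy Group

The source may hold more compounds than are shown below. What is called first, only, known or untested is meant among the compounds shown, and "the series" means these compounds.

Compound 1: `Cc1cc(C2=NN(c3ccc(S(C)(=O)=O)cc3)C(=O)CC2)ccc1O` — 26.6%
Compound 2: `COc1ccc(C2=NN(c3ccc(S(C)(=O)=O)cc3)C(=O)CC2)cc1OC` — 66.6%

Of the compounds shown here, two sharing one core have been measured in a functional assay on the whole organism (strain Wistar) for inhibition, with Rattus norvegicus as the target, read by paw edema, with stated times of 30 min and 3 h, at a dose of 0.05 mmol/kg by the oral route; on this read-out lower numbers stand for less inhibition and higher numbers for more inhibition at the one dose given (going by the name of the read-out). Compound 1 gives 26.6%, the lower of the two numbers. For the measured compounds named here, compound 2 gives 66.6%, and the gap between these two values lies beyond the usual scatter of repeated measurements; no step between them is computed here, so only the two values themselves speak.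

Compound 3, `CS(=O)(=O)c1ccc(N2N=C(c3ccc(O)c(Cl)c3)CCC2=O)cc1`, has not yet been measured in this assay . It differs from compound 1 in a single place: chloro in place of methyl on an aromatic carbon. One heavy atom leaves and one heavy atom enters, with no change in ring count, hydrogen-bond donors or acceptors, or charge.

Going by the values given here, nothing among the measured compounds shows how this exchange moves the read-out, so no direction can be read from the data. A swap of this size is expected to move the number little, with the step of a number 6.4 percentage points higher from compound 1 to compound 3 (within the scatter) estimated to stay near or within the scatter. Compound 3 is therefore expected to give about 33%, with a range from 15% to 58%.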

Compound 3, a percentage reported as inhibition, in the whole organism at one dose (the size of the read-out at that dose, not a potency): 43.3%
Beside the measured number, compound 3's estimate is 10.3 percentage points below it; low and high end bracket the measured number.
By their numbers in this assay, from the lowest: compound 1; then compound 3; then compound 2.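

In this assay, chloro in place of methyl on this aromatic carbon, ortho to a hydroxy group, gives a number 16.7 percentage points higher from compound 1 to compound 3 (beyond the scatter) and so shows that the read-out responds to what sits at this one position. The exchange swaps one heavy atom for another and leaves the counts of rings, hydrogen-bond donors and hydrogen-bond acceptors unchanged, as well as the charge, so even a small edit here can matter. Compound 1 and compound 2 differ in more than one place and could not tie any change in the read-out to a single position, whereas this pair does; no measurement of any property of these groups accompanies the result, and the data offer no explanation for the step.

With only methyl and chloro shown at this carbon, it remains open whether other small groups, such as fluoro, bromo, nitrile or an amine, would raise the number further, leave it level or lower it. On these data alone, it also remains open whether chloro in place of methyl would give a similar step if the hydroxy group were replaced by a methoxy group.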